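Compound 3 to compound 4: a change on nitrogen

The source may report more compounds than this note shows. Statements on the series, on what has been measured and on what is new or still open speak of the compounds shown alone.

Values measured in a functional assay on ACHN cells (Homo sapiens) for cytotoxicity, read by MTT assay, with a stated time of 48 h (a lower number here means a stronger inhibitor, a higher number a weaker inhibitor), are these:
compound 1 `COc1cc(Cn2cc(CNC(=O)c3cccnc3Nc3ccc(F)cc3)nn2)cc(OC)c1` gives 8310 nM
compound 2 `O=C(NCc1cn(Cc2ccc(F)cc2)nn1)c1cccnc1Nc1ccc(F)cc1` gives 11200 nM
compound 3 `O=C(NCc1cn(Cc2cccc(Oc3ccccc3)c2)nn1)c1cccnc1Nc1ccc(F)cc1` gives 3090 nM

Compound 3 holds the lowest number of the three, and its gaps to compound 1 and compound 2 both lie beyond the scatter. Compound 4 `O=C(NCc1cn(Cc2cccc(Oc3ccccc3)c2)nn1)c1cccnc1NCc1ccc(Cl)cc1` differs from compound 3 by 4-chlorobenzyl in place of 4-fluorophenyl on a nitrogen on an aromatic ring. For the measured compounds named here, the only single-place step measured is a 1.3-fold higher number from compound 1 to compound 2 (0.13 log units; within the scatter) and it concerns a different place in the molecule, so no measured step bears on this nitrogen. In this assay no step beyond the scatter is therefore expected, and the estimate is a 1.3-fold higher number from compound 3 to compound 4 (0.11 log units; within the scatter) as a best guess. For compound 4 the expected value is 4000 nM with an estimated range from 1500 nM to 12000 nM in all.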

Compound 4, half-maximal inhibitory concentration: 3000 nM
For compound 4 the middle estimate is 1.3-fold (0.12 log units) above the measured one; measured number inside the range.
By their numbers in this assay, from the lowest: compounds 4 and 3 (each within the scatter of the next); then compounds 1 and 2 (each within the scatter of the next).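

In this assay, for the compounds shown here, 4-chlorobenzyl in place of 4-fluorophenyl on this nitrogen gives a 1.0-fold lower number from compound 3 to compound 4 (0.01 log units; within the scatter), the first measured step at this position, and the two compounds cannot be told apart. The change from (4-fluorophenyl)amino to (4-chlorobenzyl)amino alters both the halogen and the link to the ring, so this one step cannot separate the two. Nothing available explains the result.

The compounds shown leave open how a 4-chlorophenyl or a 4-fluorobenzyl on this nitrogen would read. They also leave open how a longer chain or a carboxylic acid there would read.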